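The source may hold more compounds than are shown below. What is called first, only, known or untested is meant among the compounds shown, and "the series" means these compounds.

Working notes on the series. Compound 1 `COc1cc(/C(Cl)=C/C=C(\C#N)C(=O)c2c[nH]c3ccccc23)cc(OC)c1OC` is the reference point; in a functional assay for inhibition, with a stated time of 30 min, tested at 1 mM (on this read-out higher numbers stand for more inhibition at the one concentration tested (going by the name of the read-out) and lower numbers for less inhibition), compound 1 gives 21.1%. Compound 2 `COc1ccc(/C(Cl)=C/C=C(\C#N)C(=O)c2c[nH]c3ccccc23)cc1OC` gives 15.8% in this assay, and the change is a number 5.3 percentage points lower from compound 1 to compound 2 (within the scatter). Compound 3 `COc1cc(/C(Cl)=C/C=C(\C#N)C(=O)c2c(C)[nH]c3ccccc23)cc(OC)c1OC` gives 14.5% in this assay, a step of a number 6.6 percentage points lower from compound 1 to compound 3 (within the scatter). All three numbers thus lie within the scatter of one another, so no ranking among compounds 1, 2 and 3 is drawn; compound 1 simply serves as the starting point for the next step.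

Compound 4 `COc1ccc2[nH]cc(C(=O)/C(C#N)=C/C=C(\Cl)c3cc(OC)c(OC)c(OC)c3)c2c1` differs from compound 1 by methoxy in place of hydrogen on an aromatic carbon. Among the compounds with values here, no measured step puts a methoxy onto the core ring; the nearest comparisons are the removal of a methoxy from the other ring in a number 5.3 percentage points lower from compound 1 to compound 2 (within the scatter) and the methyl placed on the core in a number 6.6 percentage points lower from compound 1 to compound 3 (within the scatter), both within the scatter. On that basis the expected step is a number 1.1 percentage points lower from compound 1 to compound 4 (within the scatter), not beyond the scatter in either direction. Compound 4 is therefore estimated at 20% in this assay, within 8% to 32%.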

Compound 4, a percentage reported as inhibition, at one concentration (the size of the read-out at that concentration, not a potency): 46.1%
Estimate against measurement, compound 4: 26.1 percentage points below; measured number above the stated range.
By their numbers in this assay, from the lowest: compounds 3, 2 and 1 (each within the scatter of the next); then compound 4.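

In this assay, methoxy in place of hydrogen on an aromatic carbon of the six-membered ring, part of a fused or bridged system of two rings, gives a number 25 percentage points higher from compound 1 to compound 4 (beyond the scatter). Within the data shown here, this is the first step from compound 1 that clears the scatter: a number 5.3 percentage points lower from compound 1 to compound 2 (within the scatter) and a number 6.6 percentage points lower from compound 1 to compound 3 (within the scatter) do not, so this position responds to this change in a way those two steps did not reveal. Nothing on hand bears on why the number rises at this position.

Going by these compounds, whether an amine, a hydroxyl group or a longer ethoxy chain on the same carbon would give a comparable step remains open. So does whether methoxy on the other carbons of that ring would do the same, and the read-out, taken at a single concentration, gives no potency for compound 4.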